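The source may report more compounds than this note shows. Statements on the series, on what has been measured and on what is new or still open speak of the compounds shown alone.

Working notes on the series. In an ADME assay on microsomes from liver (Homo sapiens) for metabolic stability, read by LC-MS, with a stated time of 30 min, tested at 1 uM (on this read-out higher numbers stand for a more stable compound and lower numbers for a less stable compound), compound 1 (`O=C(NCc1ccc(S(=O)(=O)N2CCCCC2)cc1)c1cnc2nccn2c1`) gives 64%, the lower of the two numbers available, and compound 2 (`O=C(NCc1ccc(S(=O)(=O)c2cc(F)cc(F)c2)cc1)c1cnc2nccn2c1`) gives 78%. Among the measured compounds shown here, the only measured step, a number 14 percentage points higher from compound 1 to compound 2 (beyond the scatter), is modest and replaces piperidin-1-yl on a sulfonyl sulfur with 3,5-difluorophenyl. Compound 3 (`O=C(NCc1ccc(S(=O)(=O)N2CCCCC2)cc1)c1cc2ccncc2o1`) keeps the piperidin-1-yl group and differs from compound 1 as follows: a group of 9 heavy atoms (7 carbon, 1 nitrogen, 1 oxygen; one five-membered aromatic ring with 1 hetero atom, one six-membered aromatic ring with 1 hetero atom) in place of a group of 9 heavy atoms (6 carbon, 3 nitrogen; one five-membered aromatic ring with 2 hetero atoms, one six-membered aromatic ring with 2 hetero atoms), on a carbonyl carbon. For the measured compounds named here, no measured step touches the carbonyl carbon place, so the one step available shows only the size of change seen so far in this assay and gives no direction. The expectation therefore rests on compound 1 with its 64%, and no step beyond the scatter is expected. The estimated step is a number 4 percentage points lower from compound 1 to compound 3 (within the scatter). Compound 3 is estimated at 60%, with an expected range from 40% to 78%.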

Compound 3, percent of the compound remaining: 56%
Beside the measured number, compound 3's estimate is 4 percentage points above it; the measured number falls inside the stated range.
By their numbers in this assay, from the lowest: compounds 3 and 1 (each within the scatter of the next); then compound 2.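

Among the compounds shown here, this is the first measured step on the carbonyl carbon, and in this assay it reads a number 8 percentage points lower from compound 1 to compound 3 (within the scatter). For the compounds shown here, with the piperidin-1-yl group held, one fused pair of aromatic rings on the carbonyl carbon can therefore be exchanged for another with different hetero atoms without a step beyond the scatter, whereas the only step beyond the scatter so far, a number 14 percentage points higher from compound 1 to compound 2 (beyond the scatter), lies on the sulfonyl sulfur. No measurement at hand explains how this exchange on the carbonyl carbon reads in this assay.

From the compounds shown here alone, it remains open whether 3,5-difluorophenyl on the sulfonyl sulfur gives a step of similar size when the group of compound 3 sits on the carbonyl carbon. Also open, going by these compounds, is how a single phenyl ring on the carbonyl carbon, or a morpholin-4-yl group on the sulfonyl sulfur, would read.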